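Swapping Thiophen-2-yl for Pyridin-4-yl on the Hydrazone Carbon

The source may hold more compounds than are shown below. What is called first, only, known or untested is meant among the compounds shown, and "the series" means these compounds.

Measured so far:
compound 1 `O=C(N/N=C/c1ccc(O)cc1)c1ccc(-c2nc3ccccc3s2)cc1`
compound 2 `O=C(N/N=C/c1cccs1)c1ccc(-c2nc3ccccc3s2)cc1`
compound 3 `COC(=O)c1ccc(/C=N/NC(=O)c2ccc(-c3nc4ccccc4s3)cc2)cc1`

In an assay on isolated protein for inhibition of Maltase-glucoamylase (Homo sapiens), with a stated time of 15 min (a higher number here means a weaker inhibitor, a lower number a stronger inhibitor), compound 1 gives 11300 nM and compound 2 gives 8480 nM. Compound 3 gives "not active" (no number reported), with no number given. Compound 2 carries the lower of the two reported numbers, though a 1.3-fold lower number from compound 1 to compound 2 (0.12 log units; within the scatter) falls within the scatter, so the two cannot be ordered.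

Compound 4 `O=C(N/N=C/c1ccncc1)c1ccc(-c2nc3ccccc3s2)cc1` differs from compound 2 by pyridin-4-yl in place of thiophen-2-yl on a carbon with a double bond to nitrogen. Among the compounds with values here, the only step that bears on this exchange is a 1.3-fold lower number from compound 1 to compound 2 (0.12 log units; within the scatter), which also swapped one aromatic ring on that carbon for another and stayed within the scatter. No step beyond the scatter is therefore expected in this assay, while the silence of compound 3 leaves some risk of a limit. Compound 4 is expected to give 10000 nM, between 4000 nM and 30000 nM. That would amount to an expected 1.2-fold higher number from compound 2 to compound 4 (0.07 log units; within the scatter).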

Compound 4, half-maximal inhibitory concentration: "not active" (no number reported)
Compound 4: no number reported; the estimate stays without a comparison.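

In this assay, within the data shown here, compound 4, like compound 3, carries no number, so no step from compound 2 can be read. The compounds shown leave open how far compound 4 lies from compound 2. No measured evidence bears on this result.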